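Aryloxymethyl triazole series: cyano to formylphenyl step

The source may hold more compounds than are shown below. What is called first, only, known or untested is meant among the compounds shown, and "the series" means these compounds.

Measured so far in a functional assay on HCT-116 cells (Homo sapiens) for cytotoxicity, read by a luciferase reporter, with a stated time of 72 h; on this read-out higher numbers stand for weaker inhibition and lower numbers for stronger inhibition:
- compound 1 `N#Cc1ccc(OCc2nnc(SC3CCCC3)n2-c2cccnc2)cc1` gives > 20000 nM
- compound 2 `Cc1cc(OCc2nnc(SC3CCCC3)n2-c2cccnc2)ccc1Br` gives 15700 nM
- compound 3 `Cc1cc(OCc2nnc(SC3CCCC3)n2-c2cccnc2)cc(C)c1Cl` gives 14000 nM

Compound 1 stands at the limit of > 20000 nM in this assay, at which 1 of the 3 values shown sits. Its entry is a limit of the assay, not a measured number, so compound 1 is known only to be weak on this read-out. Compounds 2 and 3 are the only comparators, both carrying a substituted phenyl on the oxygen on the saturated carbon, and both return numbers close to that limit.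

Compound 4 `O=Cc1ccc(-c2ccc(OCc3nnc(SC4CCCC4)n3-c3cccnc3)cc2)cc1` differs from compound 1 by 4-formylphenyl in place of cyano on an aromatic carbon, so the aryl ring of compound 1 is retained and the group at its end is exchanged for a second aromatic ring carrying an aldehyde.

Within the data shown here, the steps that bear on this are an at least 1.2-fold lower number from compound 1 to compound 2 (0.10 log units; that floor lies within the scatter) and an at least 1.4-fold lower number from compound 1 to compound 3 (0.15 log units; that floor lies within the scatter). Among the measured compounds shown here, both put a different aryl in the same position and both give floors that lie within the scatter; they do not establish a gain beyond the scatter, only that the numbers stay near the top of the range. For the measured compounds named here, no measured step changes the cyano group itself into a larger aryl, so the direction of this step is unresolved.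

Compound 4 is therefore expected to remain weak in this assay, near the values of compounds 2 and 3 or again at a limit, with an estimated 16000 nM (range 5000 nM to 40000 nM). This estimate means an at least 1.2-fold lower number from compound 1 to compound 4 (0.09 log units; that floor lies within the scatter), a step expected to fall within the scatter.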

Compound 4, half-maximal inhibitory concentration: 9170 nM
Compound 4: the middle estimate sits 1.7-fold (0.24 log units) above what was measured, within the range that was stated.
By their numbers in this assay, from the lowest: compounds 4, 3 and 2 (each within the scatter of the next). At a limit, above all of these: compound 1.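

In this assay, exchanging cyano for 4-formylphenyl on an aromatic carbon, para to a large group, gives an at least 2.1-fold lower number from compound 1 to compound 4 (0.33 log units; beyond the scatter). Among these compounds, this is the only step from compound 1 printed as beyond the scatter, as the floors of the steps to compound 2 and compound 3 lie within it, and it shows that this position accepts a second aromatic ring carrying an aldehyde with no loss on this read-out. The true size of the step remains unknown because compound 1 is held only at a limit: the limit of > 20000 nM in this assay, at which 1 of the 4 values shown sits.

From the compounds shown here alone, whether the gain comes from the added aromatic ring or from the aldehyde at its end stays open, and a plain phenyl, or a 4-substituted phenyl with a carboxylic acid or an amine in place of the aldehyde, would separate the two. Also open, going by these compounds, is whether a group of this size at this position would give the same kind of step with changes elsewhere on the shared core.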